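A few compounds are considered here, and "the series" means these few. Any claim that something is new, unique, unknown or untested is made for them only; others in the source may bear on it.

Measured so far in an assay on isolated protein with Bile acid receptor (Homo sapiens) as the target; a higher number here means that more compound is needed for the effect, a lower number that less compound is needed:
compound 1 `COC(=O)/C=C/c1cccc(N(Cc2ccc(/C=C/c3ccccn3)cc2)C(=O)C2CCCCC2)c1`: 309 nM
compound 2 `COC(=O)/C=C/c1cccc(N(Cc2ccc(-c3ccc(OC(F)(F)F)cc3)cc2)C(=O)C(C)C)c1`: 219 nM

Compound 1 shows the higher of the two numbers, but its value and that of compound 2 lie within the usual scatter of each other, so no order between them can be read from these two points. Compound 3 `COC(=O)/C=C/c1cccc(N(Cc2ccc(-c3ccc(SC)cc3)cc2)C(=O)C2CCCCC2)c1` has not been measured. It differs from compound 1 in one place: 4-(methylsulfanyl)phenyl in place of 2-(pyridin-2-yl)ethenyl on an aromatic carbon. Going by the values given here, no measured pair covers this change, so its size is unknown. Compound 3 is expected to give 220 nM in this assay, in the range 80 nM to 600 nM, in part because compound 2 gives 219 nM with a related group in the same place. The step of a 1.4-fold lower number from compound 1 to compound 3 (0.15 log units; within the scatter) is expected to stay within the scatter.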

Compound 3, half-maximal effective concentration: 69 nM
Compound 3: middle estimate off by 3.2-fold (0.50 log units), on the high side; measured number outside the range, below it.
By their numbers in this assay, from the lowest: compound 3; then compounds 2 and 1 (each within the scatter of the next).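

At this aromatic carbon, para to a large group, the choice of substituent moves the read-out: in this assay, 4-(methylsulfanyl)phenyl in place of 2-(pyridin-2-yl)ethenyl gives a 4.5-fold lower number from compound 1 to compound 3 (0.65 log units; beyond the scatter). The two groups have the same heavy-atom and hydrogen-bond-acceptor counts, so those counts alone do not distinguish them. Nothing at hand explains the step.

The compounds shown do not separate the contribution of the sulfur from that of the ring nitrogen or the double bond. From the compounds shown here alone, how a 4-methoxyphenyl or 4-(methylamino)phenyl group would compare at this position remains open.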